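Working notes: methoxy to methyl on the chain carbon

The compounds below may be only part of what the source reports. "The series", "measured", "known", "first", "only" and "open" are said of these compounds alone.

compound 1 `COCC(C(=O)N1CCN(c2cccc(C(F)(F)F)c2)CC1)N1C(=O)CCC1=O` — > 120 mg/kg
compound 2 `CC(C(=O)N1CCN(c2ccccc2C(F)(F)F)CC1)N1C(=O)CCC1=O` — 87.1 mg/kg

In a functional assay on the whole organism (strain Swiss) with Mus musculus as the target, with a stated time of 0.25 h (a higher number here means that more compound is needed for the effect, a lower number that less compound is needed), compound 1 reaches only a limit, > 120 mg/kg. Compound 2 gives a number in this assay, 87.1 mg/kg. Compound 2 differs from compound 1 in more than one place, so the two values are set side by side without a step between them; they show a limit for compound 1 and a measured dose for compound 2, nothing more. Among the measured compounds shown here, the only quantitative evidence on compound 1 is the limit of > 120 mg/kg in this assay, at which 1 of the 2 values shown sits.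

Compound 3 `CCC(C(=O)N1CCN(c2cccc(C(F)(F)F)c2)CC1)N1C(=O)CCC1=O` is not yet measured. It differs from compound 1 by methyl in place of methoxy on a saturated chain carbon, two bonds along the chain from an amide-type nitrogen in a ring and a carbonyl carbon. For the measured compounds named here, because compound 1 sits at the limit of > 120 mg/kg in this assay, at which 1 of the 2 values shown sits, no step can be fixed for it; whether the ethyl analogue falls within the measurable range or again runs to a limit is open. Compound 3 is expected to land at about 120 mg/kg, with a range from 60 mg/kg to 250 mg/kg, which is an expected step of a number no higher from compound 1 to compound 3 (the limit leaves the size open) from the limit of compound 1 and may well lie inside the usual scatter.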

Compound 3, dose for half-maximal effect: 83.2 mg/kg
Compound 3: middle estimate off by 1.4-fold (0.16 log units), on the high side, and the stated range covers the measured number.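

Among the compounds shown here, the first single-place step concerns the chain carbon: methoxy gives way to methyl there, two bonds along the chain from an amide-type nitrogen in a ring and a carbonyl carbon, and the reading in this assay is an at least 1.4-fold lower number from compound 1 to compound 3 (0.15 log units; that floor lies within the scatter). Compound 1 remains a limit, > 120 mg/kg, and not a number. Compound 3 now supplies a measured dose on this same core, so the position can yield a number in this assay, but the step has only a floor and its true size stays unfixed: the limit of > 120 mg/kg in this assay, at which 1 of the 3 values shown sits.

From the compounds shown here alone, it remains open whether the methoxymethyl to ethyl change is truly a small step or one that goes beyond the scatter, which only a number for compound 1 could settle. Also open, going by these compounds, is how a longer chain such as propyl, or a hydroxymethyl or aminomethyl group on this saturated chain carbon, would read against the dose of compound 3, 83.2 mg/kg.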